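From 3-chlorophenyl to 4-fluorophenyl on the carbonyl

A few compounds are considered here, and "the series" means these few. Any claim that something is new, unique, unknown or untested is made for them only; others in the source may bear on it.

In a functional assay on MDA-MB-231 cells (Homo sapiens) for antiproliferative activity, read by MTT assay, with a stated time of 24 h (a lower number here means a stronger inhibitor, a higher number a weaker inhibitor), compound 1 `O=C(NNc1cccc(Cl)c1)c1cccc(NS(=O)(=O)c2cnc(O)nc2O)c1` gives 7760 nM. Compound 2 `Cc1ccc(C(=O)NNC(=O)c2cccc(NS(=O)(=O)c3cnc(O)nc3O)c2)cc1` reaches only a limit of the assay, > 20000 nM. Compound 3 `O=C(NNC(=O)c1cccc(NS(=O)(=O)c2cnc(O)nc2O)c1)c1cccc(Cl)c1` gives 3180 nM, the lowest number in the series, and its nearest neighbour is reached by a 2.4-fold lower number from compound 1 to compound 3 (0.39 log units; beyond the scatter).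

Compound 4 `O=C(NNC(=O)c1cccc(NS(=O)(=O)c2cnc(O)nc2O)c1)c1ccc(F)cc1` keeps the shared core and changes one group: 4-fluorophenyl in place of 3-chlorophenyl on a carbonyl carbon. In words, 4-fluorophenyl stands in place of 3-chlorophenyl on a carbonyl carbon. The measured step that bears most directly on this is an at least 6.2-fold lower number from compound 2 to compound 3 (0.79 log units; beyond the scatter), made at the same place, where 3-chlorophenyl replaced 4-methylphenyl. For the measured compounds named here, compound 4 likewise gives up nothing else, but it loses the 3-chlorophenyl group that accompanies the lowest number, so a move toward weaker inhibition is expected, though with no measured fluorine example the size remains uncertain. The expected change is a 2.5-fold higher number from compound 3 to compound 4 (0.40 log units; beyond the scatter). For compound 4 the estimated value is 8000 nM, with an expected range of 3000 nM to 20000 nM.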

Compound 4, half-maximal inhibitory concentration: > 20000 nM
Compound 4: a limit, no number; the forecaster's own chance of this, stated with the estimate: 20%; middle value at least 2.5-fold (0.39 log units) away from the limit.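

Compound 4 sits at a limit of the assay rather than a number in this assay, and it shares that limit with compound 2: the limit of > 20000 nM in this assay, at which 2 of the 4 values shown sit.

For the compounds shown here, on this carbonyl carbon, 4-methylphenyl had been the only comparison for 3-chlorophenyl; with 4-fluorophenyl, a second group also fails to give a readable number, the step being an at least 6.2-fold higher number from compound 3 to compound 4 (0.79 log units; beyond the scatter). The (4-fluorophenyl)carbonyl group also does not carry over the gain seen with (3-chlorophenyl)carbonyl on the amine nitrogen, the step here being an at least 2.5-fold higher number from compound 1 to compound 4 (0.41 log units; beyond the scatter).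

The step between compound 2 and compound 4 cannot be read, since both values are limits, so fluoro and methyl remain unranked on that aromatic carbon. Also open, on these data alone, is whether the lower number of compound 3 follows the chlorine or its 3-position, which a 4-chlorophenyl or 3-fluorophenyl group on this carbonyl carbon would separate.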